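Swapping cyclohexyl for phenyl in a weak HepG2 cytotoxin

The source may report more compounds than this note shows. Statements on the series, on what has been measured and on what is new or still open speak of the compounds shown alone.

- Compound 1 `O=C(NC1CCCCC1)Oc1ccccc1C(=O)Nc1ccccc1`: 49000 nM
- Compound 2 `O=C(Nc1ccccc1)Oc1ccc(Cl)cc1C(=O)Nc1ccc(Br)cc1`: > 50000 nM (a limit)
- Compound 3 `O=C(Nc1ccccc1)Oc1ccc(Cl)cc1`: > 125000 nM (a limit)

For the measured compounds named here, in an ADME assay on HepG2 cells (Homo sapiens) for cytotoxicity, read by MTT assay (on this read-out lower numbers stand for stronger inhibition and higher numbers for weaker inhibition), compound 1 gives 49000 nM, the only exact number in this small set. Compound 2 is reported only as a limit, > 50000 nM. Compound 3 is likewise reported only as a limit, > 125000 nM.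

The next compound to be tested is compound 4 `O=C(Nc1ccccc1)Oc1ccccc1C(=O)Nc1ccccc1`. It differs from compound 1 in one place, with phenyl in place of cyclohexyl on an amide-type nitrogen. Going by the values given here, no pair of measured compounds shows this swap on its own, so the expectation rests on indirect evidence. Compound 2 and compound 3 both carry phenyl on that kind of nitrogen, and neither gave an exact number. That points towards weak inhibition for compound 4 as well, so no large gain in strength is expected. The expected change is a 1.2-fold higher number from compound 1 to compound 4 (0.09 log units; within the scatter), a small step that would hardly stand out from the ordinary scatter of repeat measurements. The assay may also return only a limit. For compound 4 the estimated value is 60000 nM, with an expected range from 25000 nM to 150000 nM.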

Compound 4, half-maximal inhibitory concentration: 57700 nM
For compound 4 the middle estimate is 1.0-fold (0.02 log units) above the measured one; the range from low to high includes it.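

In this assay, for the compounds shown here, exchanging cyclohexyl for phenyl on an amide-type nitrogen gives a 1.2-fold higher number from compound 1 to compound 4 (0.07 log units; within the scatter), the first direct reading of this swap in the set. At this position, then, an aromatic six-membered carbon ring and a non-aromatic one cannot be told apart by this read-out, so the aromatic character of the ring shows no measurable effect on the number here. Compound 2, which also carries phenyl on such a nitrogen, is reported only as a limit, and this small step lies in the same weak part of the scale: the limit of > 50000 nM in this assay, at which 1 of the 4 values shown sits.

The compounds shown leave open whether a group of a different kind on this nitrogen, such as a short chain like methyl or a phenyl ring carrying a carboxylic acid or an amine, would move the number beyond the scatter. They also leave open whether the swap would give the same small step on the chlorine- and bromine-bearing compound 2, whose limit gives no exact number to compare against.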